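The source may report more compounds than this note shows. Statements on the series, on what has been measured and on what is new or still open speak of the compounds shown alone.

Measured compounds:
compound 1 `CCN(CC)c1nc(Nc2cccc(C(=O)O)c2)nc(OC(C(F)(F)F)C(F)(F)F)n1` — 160 nM
compound 2 `CCN(CC)c1nc(Nc2cccc(F)c2)nc(OC(C(F)(F)F)C(F)(F)F)n1` — 140 nM

In an assay on cells for activation of Cystic fibrosis transmembrane conductance regulator (Homo sapiens), read by fluorescence, with stated times of 10 min and 12 s (on this read-out lower numbers stand for an effect already at smaller amounts and higher numbers for an effect only at larger amounts of compound), compound 1 gives 160 nM, the higher of the two numbers recorded so far; its nearest neighbour is compound 2, which in this assay gives 140 nM, and the two values sit within the scatter of each other.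

Compound 3 `CCN(CC)c1nc(Nc2cccc(Cl)c2)nc(OC(C(F)(F)F)C(F)(F)F)n1` has not yet been measured in this assay. It differs from compound 1 in one place: chloro in place of carboxy on an aromatic carbon.

Among the compounds with values here, one measured step bears on this change. The replacement of the carboxy group by fluoro, from compound 1 to compound 2, gave a 1.1-fold lower number from compound 1 to compound 2 (0.06 log units; within the scatter), so exchanging the carboxy group for a small substituent on that aromatic carbon left the number essentially unchanged. Chloro is, like fluoro, a single halogen atom at the same place, with no donor and no acceptor. On that basis the step from compound 1 to compound 3 is expected to be a 1.1-fold lower number from compound 1 to compound 3 (0.06 log units; within the scatter), with no shift beyond the scatter. Compound 3 is therefore estimated at 140 nM in this assay, with a likely range from 60 nM to 350 nM.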

Compound 3, half-maximal effective concentration: 2800 nM
Compound 3: the middle estimate sits 20-fold (1.30 log units) below what was measured; the measured number lies above the stated range.
By their numbers in this assay, from the lowest: compounds 2 and 1 (each within the scatter of the next); then compound 3.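

In this assay this aromatic carbon proves sensitive to which substituent it carries: chloro in place of carboxy gives an 18-fold higher number from compound 1 to compound 3 (1.24 log units; beyond the scatter) and chloro in place of fluoro gives a 20-fold higher number from compound 2 to compound 3 (1.30 log units; beyond the scatter) as the second measured change at the same place. Compound 1 and compound 2 sit within the scatter of each other, so their agreement describes only those two groups and does not extend to every small substituent; a single halogen atom at this carbon does not settle the outcome, since fluoro and chloro part clearly here. No measurement at hand accounts for this difference between the two halogens.

Going by these compounds, whether compound 3 is a case particular to chloro or the first of a wider set stays open, and bromo, methyl or a nitrile on the same aromatic carbon would bear on that. Equally open, on these data alone, is whether an amine or an amide at this carbon would stay with compound 1 and compound 2 or fall with compound 3.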